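This account rests on a few compounds, and the source may have more. Where it says the series, first, only, none or still open, it means among the compounds named here.

Compound 3, `CC(C)(C)[C@H]1CC[C@]2(CC1)N=C(c1cccc(Cl)c1)C(=O)N2Cc1ccc(C(=O)NCCC(=O)O)cc1`, is one of three compounds built on a shared core and measured in a functional assay on CHO cells for antagonist activity at Glucagon receptor (Homo sapiens), read by cAMP accumulation, with stated times of 30 min and 45 min; on this read-out lower numbers stand for stronger inhibition and higher numbers for weaker inhibition. In this assay compound 3 gives 770 nM. Compound 1, `CC(C)(C)[C@H]1CC[C@]2(CC1)N=C(c1cccc(C(F)(F)F)c1)C(=O)N2Cc1ccc(C(=O)NCCC(=O)O)cc1`, gives 510 nM in this assay, and compound 2, `CC(C)(C)[C@H]1CC[C@]2(CC1)N=C(c1ccc(Cl)c(Cl)c1)C(=O)N2Cc1ccc(C(=O)NCCC(=O)O)cc1`, gives 1600 nM. On these numbers compound 3 stands second highest of the three: its nearest neighbour is compound 1, within the scatter, and its furthest is compound 2, as seen in a 2.1-fold lower number from compound 2 to compound 3 (0.32 log units; beyond the scatter).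

Compound 4, `CC(C)(C)[C@H]1CC[C@]2(CC1)N=C(c1ccc(Cl)cc1)C(=O)N2Cc1ccc(C(=O)NCCC(=O)O)cc1`, has not yet been measured in this assay. It differs from compound 3 in one place: 4-chlorophenyl in place of 3-chlorophenyl on a carbon with a double bond to nitrogen. Among the compounds with values here, no measured step moves a chloro from one position of this aromatic ring to another, so none bears on the change directly. The steps that come nearest are a 2.1-fold lower number from compound 2 to compound 3 (0.32 log units; beyond the scatter), in which a chloro leaves the ring, a 1.5-fold higher number from compound 1 to compound 3 (0.18 log units; within the scatter), in which a chloro replaces a trifluoromethyl, and a 3.1-fold higher number from compound 1 to compound 2 (0.50 log units; beyond the scatter). Each of these is modest or within the scatter, so a modest step is expected in this assay, if any beyond the scatter, with a somewhat higher number the more likely direction. Compound 4 is therefore estimated at 1000 nM, with a range from 400 nM to 2500 nM. The expected step is a 1.3-fold higher number from compound 3 to compound 4 (0.11 log units; within the scatter).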

Compound 4, half-maximal inhibitory concentration: 1400 nM
Beside the measured number, compound 4's estimate is 1.4-fold (0.15 log units) below it; the range from low to high includes it.
By their numbers in this assay, from the lowest: compounds 1, 3, 4 and 2 (each within the scatter of the next, the first and the last beyond it).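

In this assay, the first direct test of where the chloro sits on this ring, 4-chlorophenyl in place of 3-chlorophenyl gives a 1.8-fold higher number from compound 3 to compound 4 (0.26 log units; within the scatter), so this move on the carbon with a double bond to nitrogen stays within the scatter. Taking a chloro from the 3,4-dichlorophenyl group to leave 4-chlorophenyl gives a 1.1-fold lower number from compound 2 to compound 4 (0.06 log units; within the scatter), also within the scatter, whereas the earlier step that left 3-chlorophenyl lay beyond it. Set against 3-(trifluoromethyl)phenyl, 4-chlorophenyl gives a 2.7-fold higher number from compound 1 to compound 4 (0.44 log units; beyond the scatter), beyond the scatter, a separation that 3-chlorophenyl did not show.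

The compounds shown carry only chloro and trifluoromethyl on this ring, so it remains open how plain phenyl, 4-fluorophenyl, 4-methoxyphenyl or 4-(trifluoromethyl)phenyl would compare with 4-chlorophenyl. As far as these compounds go, the tert-butyl group and the chain ending in a carboxylic acid are the same throughout, so it is also open whether these small steps would hold with an amine or a longer chain in that place. Nothing given here accounts for the differences between these compounds.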